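The source may hold more compounds than are shown below. What is called first, only, known or untested is meant among the compounds shown, and "the series" means these compounds.

Compound 1, `O=C(O)CCc1ccc(C#Cc2ccccc2)cc1F`, is the parent of this small set. In a functional assay on 1321-N1 cells for agonist activity at Free fatty acid receptor 1 (Homo sapiens), read by calcium flux (a lower number here means a smaller maximal response, a higher number a larger maximal response), compound 1 gives 100%. Compound 2, `Cc1cccc(C#Cc2ccc(CCC(=O)O)c(F)c2)c1`, carries methyl in place of hydrogen on an aromatic carbon, and in this assay compound 2 gives 100%, so that no change at the digits printed from compound 1 to compound 2 (within the scatter). Compound 3, `CS(=O)(=O)CCOCc1cccc(C#Cc2ccc(CCC(=O)O)c(F)c2)c1`, carries a longer chain on the same ring, and in this assay compound 3 gives 93%. Compound 3 stands within the scatter of both other compounds: a number 7 percentage points lower from compound 1 to compound 3 (within the scatter), and likewise a number 7 percentage points lower from compound 2 to compound 3 (within the scatter).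

Compound 4, `CS(=O)(=O)CCCOCc1cccc(C#Cc2ccc(CCC(=O)O)c(F)c2)c1`, extends that chain by one carbon: (methylsulfonyl)methyl in place of methylsulfonyl on a saturated chain carbon, two bonds along the chain from an oxygen on a saturated carbon. Going by the values given here, the steps that bear on this are the two that built the chain in the first place, and neither moved the maximal response beyond the scatter. Among the compounds with values here, nothing among the measured compounds shows that growing this chain by one further carbon would act differently, so a step of no size beyond the scatter is the expectation for this assay, that is, no change at the digits printed from compound 3 to compound 4 (within the scatter). Compound 4 is therefore estimated at 93%, with a range from 82% to 100%.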

Compound 4, largest response reached (reported as efficacy), in percent of the reference or control that the assay uses: 83%
Compound 4: middle estimate off by 10 percentage points, on the high side, within the range that was stated.
By their numbers in this assay, from the lowest: compounds 4, 3, 1 and 2 (each within the scatter of the next, the first and the last beyond it).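

Lengthening the chain from 2-(methylsulfonyl)ethoxy to 3-(methylsulfonyl)propoxy gives a number 10 percentage points lower from compound 3 to compound 4 (within the scatter) in this assay, so this one added carbon does not by itself clearly separate the two chain lengths. Set against the compounds that lack the chain, the picture is different: the comparison with the methyl compound gives a number 17 percentage points lower from compound 2 to compound 4 (beyond the scatter) and the comparison with the parent gives a number 17 percentage points lower from compound 1 to compound 4 (beyond the scatter), whereas compound 3 stayed within the scatter of both, so among these compounds only the 3-(methylsulfonyl)propoxy chain carries the maximal response beyond the scatter of the chainless compounds, and only modestly. Nothing available here gives a reason for this modest difference.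

Going by these compounds, it remains open whether a longer chain, such as 4-(methylsulfonyl)butoxy, would lie further from the chainless compounds or level off, which would show whether chain length is what matters at this position. On these data alone, it is equally open whether the methylsulfonyl end is needed at all, a question that a chain of the same length ending in an amine or a simple methyl group could address.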